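The source may report more compounds than this note shows. Statements on the series, on what has been measured and on what is new or still open speak of the compounds shown alone.

For the measured compounds named here, compound 2 `Cc1cc(C)c(NC(=O)N(Cc2ccc(-c3cccs3)cc2)C2CCCCCC2)c(C)c1` gives 0.28 mg/kg in a functional assay on a cell-free system (plasma) with sterol O-acyltransferase, Soat (Rattus norvegicus) as the target (a higher number here means that more compound is needed for the effect, a lower number that less compound is needed), the only plain number among the three measured compounds. Compound 1 `O=C(Nc1c(F)cc(F)cc1F)N(Cc1ccc(-c2cccs2)cc1)C1CCCCCC1` gives only a limit, > 1 mg/kg (the limit of > 1 mg/kg in this assay, at which 1 of the 3 values shown sits). Compound 3 `Cc1cc(C)c(NC(=O)N(Cc2cccc(-c3ccn(C)n3)c2)C2CCCCCC2)c(C)c1` likewise gives only a limit, < 1 mg/kg (the limit of < 1 mg/kg in this assay, at which 1 of the 3 values shown sits). Going by the values given here, the one step with both ends measured, an at least 3.5-fold lower number from compound 1 to compound 2 (0.55 log units; beyond the scatter), concerns the group on the amide-type nitrogen, not the position changed here. Compound 4 `Cc1cc(C)c(NC(=O)N(Cc2ccc(-n3cncn3)cc2)C2CCCCCC2)c(C)c1` differs from compound 2 by 1H-1,2,4-triazol-1-yl in place of thiophen-2-yl on an aromatic carbon. Among the compounds with values here, no measured step bears on this change, and compound 3 shows only a limit, so the direction is open. Compound 4 is therefore expected to show at most a modest step, a 1.8-fold higher number from compound 2 to compound 4 (0.25 log units; within the scatter), in this assay. The estimated value for compound 4 is 0.5 mg/kg, within 0.15 mg/kg to 1.5 mg/kg.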

Compound 4, dose for half-maximal effect: > 1 mg/kg
Compound 4: no number, only a limit (the forecaster's own chance of this, stated with the estimate: 30%); middle value at least 2.0-fold (0.30 log units) away from the limit.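

At this place, para to a large group, this assay now has a measured direction: 1H-1,2,4-triazol-1-yl in place of thiophen-2-yl gives an at least 3.5-fold higher number from compound 2 to compound 4 (0.55 log units; beyond the scatter). Both groups are five-membered aromatic rings, so the step goes with the change in hetero atoms, sulfur leaving and nitrogen entering. On these data alone, compound 4 gives > 1 mg/kg, which is a limit and not a number, so the full size of the step is unknown: the limit of > 1 mg/kg in this assay, at which 2 of the 4 values shown sit.

As far as these compounds go, what a phenyl ring or a carboxylic acid would give at this place remains open. Steps involving compound 3 cannot be read.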